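Swapping a phenyl for a cyclohexyl in an aminopyrimidine amide

A few compounds are considered here, and "the series" means these few. Any claim that something is new, unique, unknown or untested is made for them only; others in the source may bear on it.

In an ADME assay on Vero cells (Chlorocebus sabaeus) for cytotoxicity, read by MTT assay (a lower number here means a stronger inhibitor, a higher number a weaker inhibitor), compound 1 `COc1ccc(NC(=O)c2cc(N(C)Cc3ccccc3)ncn2)cc1` gives 287000 nM. Its close relative compound 2 `CN(Cc1ccccc1)c1cc(C(=O)Nc2ccccc2)ncn1` gives 314000 nM in this assay, and the step of a 1.1-fold higher number from compound 1 to compound 2 (0.04 log units; within the scatter) shows that the two stand together, neither separated from the other beyond the scatter of the measurement. Going by the values given here, compound 2 therefore occupies the same ground as the only other compound measured.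

Compound 3 `CN(CC1CCCCC1)c1cc(C(=O)Nc2ccccc2)ncn1` has not yet been tested. Relative to compound 2 the change is cyclohexyl in place of phenyl on a saturated chain carbon bound to a nitrogen on an aromatic ring. Among the compounds with values here, the single measured step, a 1.1-fold higher number from compound 1 to compound 2 (0.04 log units; within the scatter), concerns a hydrogen in place of methoxy on an aromatic carbon and does not touch the part of the molecule that changes here, so no measured step bears directly on the move from compound 2 to compound 3. With nothing in the data pointing either way, the step of a 1.0-fold lower number from compound 2 to compound 3 (0.02 log units; within the scatter) is expected to stay within the scatter. On that basis compound 3 is estimated to give 300000 nM in this assay, with a likely range from 150000 nM to 600000 nM.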

Compound 3, half-maximal inhibitory concentration: 178000 nM
The estimate for compound 3 lay 1.7-fold (0.23 log units) above the measured number; measured number inside the range.
By their numbers in this assay, from the lowest: compounds 3, 1 and 2 (each within the scatter of the next).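

Going by these compounds alone, the step of a 1.8-fold lower number from compound 2 to compound 3 (0.25 log units; within the scatter) is the first measurement at this position, on a saturated chain carbon bound to a nitrogen on an aromatic ring, where the earlier pair had differed only by hydrogen in place of methoxy on an aromatic carbon. In this assay, an aromatic six-membered ring of carbon and a non-aromatic one can therefore be exchanged here, phenyl for cyclohexyl or benzyl for cyclohexylmethyl when cut one bond further out, without the two compounds separating beyond the scatter. No measurement at hand offers an explanation for the size of this step, so the result stands only as an observation for this single pair.

Within the data shown here, the two compounds show only that this one exchange of carbon rings stays within the scatter, and they do not show whether an amine, a carboxylic acid or a longer chain at the same place would also do so in this assay. On these data alone, it also remains open whether methoxy in place of hydrogen on the aromatic carbon would give a step of similar size in the cyclohexyl series.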